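A few compounds are considered here, and "the series" means these few. Any claim that something is new, unique, unknown or untested is made for them only; others in the source may bear on it.

Compound 1 `CN(c1ccc2cc(NC(=O)CCc3ccc(C(F)(F)F)cc3)ccc2n1)C1CCCCC1`: 18 nM
Compound 2 `Nc1ccc2cc(NC(=O)CCc3ccc(C(F)(F)F)cc3)ccc2n1`: 240 nM

In an assay on isolated protein for displacement of a labelled ligand from melanin-concentrating hormone receptor 1 (Homo sapiens) (a lower number here means a stronger inhibitor, a higher number a weaker inhibitor), compound 2 gives 240 nM, the highest of the two numbers, while compound 1 gives 18 nM. Compound 3 `O=C(CCc1ccc(C(F)(F)F)cc1)Nc1ccc2nc(N3CC4CC3CO4)ccc2c1` carries a group of 7 heavy atoms (5 carbon, 1 nitrogen, 1 oxygen; 2 five-membered non-aromatic rings with 1 hetero atom each) in place of one nitrogen atom, on an aromatic carbon. Within the data shown here, one measured step bears on this: a 13-fold higher number from compound 1 to compound 2 (1.12 log units; beyond the scatter), a large change in which a substituted amine gave way to the bare amino group. Compound 3 goes the opposite way, again placing a substituted amine on that aromatic carbon, so a sizeable fall in the number is expected, a 9.6-fold lower number from compound 2 to compound 3 (0.98 log units; beyond the scatter). For compound 3 the estimate is 25 nM, in the range 7 nM to 90 nM.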

Compound 3, half-maximal inhibitory concentration: 13 nM
Compound 3: middle estimate off by 1.9-fold (0.28 log units), on the high side; the range from low to high includes it.
By their numbers in this assay, from the lowest: compounds 3 and 1 (each within the scatter of the next); then compound 2.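

On the aromatic carbon next to the ring nitrogen in this assay, a second substituted amine also beats the bare amino group, with an 18-fold lower number from compound 2 to compound 3 (1.27 log units; beyond the scatter). Set against the cyclohexyl(methyl)amino group, the oxygen-bearing two-ring group gives a 1.4-fold lower number from compound 1 to compound 3 (0.14 log units; within the scatter), so this position accepts two quite different ring amines equally well. Nothing measured here explains the result.
The compounds shown leave open whether a small amine such as dimethylamino would do as well. They also leave open whether a nitrogen must link this position at all, as a phenyl ring attached directly through carbon would test.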